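The source may report more compounds than this note shows. Statements on the series, on what has been measured and on what is new or still open speak of the compounds shown alone.

Compound 1 `O=C1N/C(=N\Cc2ccc(C(F)(F)F)cc2)S/C1=C1/CCNC(=O)c2[nH]ccc21`: > 50000 nM
Compound 2 `Cc1ccc(C/N=C2\NC(=O)/C(=C3\CCNC(=O)c4[nH]ccc43)S2)cc1`: 6830 nM

For the measured compounds named here, in a functional assay on HT-29 cells (Homo sapiens) for inhibition, read by MTT assay, with a stated time of 48 h (a higher number here means a weaker inhibitor, a lower number a stronger inhibitor), compound 2 gives 6830 nM, the only exact number so far. Compound 1 gives > 50000 nM, and this reading is a limit of the assay. Going by the values given here, the one measured step, an at least 7.3-fold lower number from compound 1 to compound 2 (0.86 log units; beyond the scatter), lies beyond the scatter and comes from methyl in place of trifluoromethyl on an aromatic carbon.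

Compound 3 `O=C1N/C(=N\Cc2ccc(F)cc2)S/C1=C1/CCNC(=O)c2[nH]ccc21` alters that same group, with fluoro in place of methyl on an aromatic carbon, para to a large group: fluoro in place of methyl on an aromatic carbon. Among the compounds with values here, since compound 1 to compound 2 is the only guide, an at least 7.3-fold lower number from compound 1 to compound 2 (0.86 log units; beyond the scatter) shows that this group can move the number in this assay, but it says nothing about fluoro itself. A modest move towards a higher number is therefore expected, and it may stay within the scatter. The expected change is a 1.6-fold higher number from compound 2 to compound 3 (0.21 log units; within the scatter). For compound 3 the estimated value is 11000 nM, with an expected range from 3500 nM to 35000 nM.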

Compound 3, half-maximal inhibitory concentration: 26000 nM
Beside the measured number, compound 3's estimate is 2.4-fold (0.37 log units) below it; low and high end bracket the measured number.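

In this assay, this position on the 4-substituted benzyl group responds even to an exchange of one heavy atom for another: a 3.8-fold higher number from compound 2 to compound 3 (0.58 log units; beyond the scatter). Methyl now gives the lowest number of the three groups at this place, with both of its steps lying beyond the scatter, so the earlier gain is not simply a matter of losing trifluoromethyl, as fluoro does not match it. The comparison of fluoro with trifluoromethyl gives only an at least 1.9-fold lower number from compound 1 to compound 3 (0.28 log units; that floor lies within the scatter), and the reading for compound 1 is a limit of the assay: the limit of > 50000 nM in this assay, at which 1 of the 3 values shown sits.

As far as these compounds go, how far fluoro and trifluoromethyl truly lie apart therefore stays open. The compounds shown also leave open how chloro, methoxy or an amine at this place would read, and whether any of them would fall below the number for methyl.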